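Swapping an allyl arm for a bromobenzyl on a weak SMYD2 scaffold

This account rests on a few compounds, and the source may have more. Where it says the series, first, only, none or still open, it means among the compounds named here.

Compound 1 `O=C1C=CC2(C=C1)OCC(Cc1cc(C(F)(F)F)cc(C(F)(F)F)c1)C(=O)N2c1ccccc1` in an assay on isolated protein for inhibition of N-lysine methyltransferase SMYD2 (Homo sapiens), read by filter binding, with a stated time of 1 h (a higher number here means a weaker inhibitor, a lower number a stronger inhibitor), gives 18500 nM.
Compound 2 `C=CCC1COC2(C=CC(=O)C=C2)N(C(C)C)C1=O` gives only a limit in this assay, > 20000 nM.
Compound 3 `CC(C)N1C(=O)C(Cc2ccc(C(F)(F)F)cc2)COC12C=CC(=O)C=C2` likewise gives only a limit, > 20000 nM.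

Compound 2 stands at the edge of what this assay can report: its value is a limit, not a number, and one further value shares that limit (the limit of > 20000 nM in this assay, at which 2 of the 3 values shown sit). Compound 4 `CC(C)N1C(=O)C(Cc2cccc(Br)c2)COC12C=CC(=O)C=C2` differs from it by one exchange, 3-bromophenyl in place of vinyl on a saturated chain carbon bound to a saturated ring carbon (allyl to 3-bromobenzyl). Going by the values given here, no measured pair shows such a step in this assay. Compound 3, which also carries a benzyl bearing a trifluoromethyl, sits at the same limit, so the change from compound 2 to compound 4 is expected to be small, within scatter, in either direction. Compound 4 is therefore estimated at 20000 nM in this assay, within 5000 nM to 60000 nM, an expected step of a number no higher from compound 2 to compound 4 (the limit leaves the size open).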

Compound 4, half-maximal inhibitory concentration: > 20000 nM
Compound 4: no number, only a limit (the forecaster's own chance of this, stated with the estimate: 60%); the middle value sits exactly at the limit.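

Going by these compounds alone, compound 2 and compound 4 each give only a limit, so no step between them can be read: the limit of > 20000 nM in this assay, at which 3 of the 4 values shown sit. The compounds shown leave open whether allyl to 3-bromobenzyl changes anything in this assay.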